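The compounds below may be only part of what the source reports. "The series", "measured", "known", "first", "only" and "open" are said of these compounds alone.

Compounds measured in an ADME assay on the whole organism for cytotoxicity, with Artemia salina as the target, with a stated time of 24 h; on this read-out lower numbers stand for an effect already at smaller amounts and higher numbers for an effect only at larger amounts of compound:

compound 1, `CCc1cc(/C=C/C(=O)c2ccccc2NC(=O)NS(=O)(=O)c2ccc(C)cc2)cc(OC)c1OC`: 19.2 ug/mL
compound 2, `Cc1ccc(S(=O)(=O)NC(=O)Nc2ccccc2C(=O)/C=C/c2cccc(O)c2)cc1`: 39.3 ug/mL
compound 3, `Cc1ccc(S(=O)(=O)NC(=O)Nc2ccccc2C(=O)/C=C/c2cc(O)ccc2[N+](=O)[O-])cc1`: 18.3 ug/mL

Compound 2 stands at the highest of the three numbers in this assay. Its nearest neighbour is compound 1, with a 2.0-fold higher number from compound 1 to compound 2 (0.31 log units; beyond the scatter); the step to compound 3, a 2.1-fold lower number from compound 2 to compound 3 (0.33 log units; beyond the scatter), is also beyond the scatter, so compound 2 is clearly set apart on this read-out.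

Compound 4, `Cc1ccc(S(=O)(=O)NC(=O)Nc2ccccc2C(=O)/C=C/c2cccc(Br)c2)cc1`, differs from compound 2 in one place: bromo in place of hydroxy on an aromatic carbon. Within the data shown here, no measured step exchanges hydroxy for bromo, so the step from compound 2 to compound 4 has no direct precedent. What the series does show is that every change at the aryl ring on the double-bonded chain carbon moved the number by a modest amount: replacing hydrogen with nitro gave a 2.1-fold lower number from compound 2 to compound 3 (0.33 log units; beyond the scatter), and the step from compound 1 to compound 2 was a 2.0-fold higher number from compound 1 to compound 2 (0.31 log units; beyond the scatter). On that basis a step of modest size is expected for compound 4, most likely toward a lower number, since compound 2 sits at the top of the observed range and both other aryl variants sit lower. The estimated step is a 1.6-fold lower number from compound 2 to compound 4 (0.21 log units; within the scatter). Compound 4 is therefore expected to give 24 ug/mL in this assay, with a range from 10 ug/mL to 58 ug/mL.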

Compound 4, concentration for half-maximal effect: 4.02 ug/mL
For compound 4 the middle estimate is 6.0-fold (0.78 log units) above the measured one; the measured number lies below the stated range.
By their numbers in this assay, from the lowest: compound 4; then compounds 3 and 1 (each within the scatter of the next); then compound 2.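

Notes on the aromatic carbon meta to a large group: in this assay the exchange of hydroxy for bromo gives a 9.8-fold lower number from compound 2 to compound 4 (0.99 log units; beyond the scatter), a larger step than any seen among the earlier compounds, whose aryl changes had stayed within a much narrower band. Among these compounds, the 3-bromophenyl group also separates compound 4 from the two other aryl variants, with a 4.6-fold lower number from compound 3 to compound 4 (0.66 log units; beyond the scatter) and a 4.8-fold lower number from compound 1 to compound 4 (0.68 log units; beyond the scatter), so this carbon and this change can shift the number well beyond what the earlier compounds showed, and compound 4 now holds the lowest number of the four, beyond the scatter against each of the others. Nothing available on the compounds accounts for the size of this step.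

Going by these compounds, whether the lower number follows from the arrival of bromo or from the loss of hydroxy stays open, and chloro, methyl or an amine on the same aromatic carbon would separate the two. Also open, on these data alone, is whether bromo would give a similar step on another carbon of this ring, or on the more heavily substituted rings of compound 1 and compound 3.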